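Series notes: a chloro added to the benzyl group

This account rests on a few compounds, and the source may have more. Where it says the series, first, only, none or still open, it means among the compounds named here.

Of the compounds shown here, two have been measured in a functional assay on HCT-116 cells (Homo sapiens) for cytotoxicity, read by MTT assay, with a stated time of 72 h; a lower number here means a stronger inhibitor, a higher number a weaker inhibitor. Compound 1 `Cc1cc(S(=O)(=O)/N=C(\N)n2nccc2-c2ccccc2)c(SCc2ccccc2)cc1Cl` gives 12000 nM in this assay; compound 2 `Cc1cc(-c2ccccc2)n(/C(N)=N/S(=O)(=O)c2cc(C)c(Cl)cc2SCc2ccccc2)n1` gives 10000 nM. Among the measured compounds shown here, the one step between them, a 1.2-fold lower number from compound 1 to compound 2 (0.08 log units; within the scatter), is a methyl in place of hydrogen on an aromatic carbon and does not separate the two compounds. Compound 1 thus holds the highest of the two numbers, with compound 2 nearest and not distinguishable from it.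

Compound 3 `Cc1cc(S(=O)(=O)/N=C(\N)n2nccc2-c2ccccc2)c(SCc2ccccc2Cl)cc1Cl` is not yet measured. It differs from compound 1 by chloro in place of hydrogen on an aromatic carbon; the change sits ortho to a large group, read one bond further out as benzyl to 2-chlorobenzyl.

For the measured compounds named here, no measured step touches this benzyl ring, so nothing speaks directly to the change. Going by the values given here, the only step available, from compound 1 to compound 2, lies within the scatter, and a single small substituent on a peripheral ring is taken, in the absence of other evidence, to behave alike. The expected step is a 1.2-fold lower number from compound 1 to compound 3 (0.08 log units; within the scatter), with no direction beyond the scatter. For compound 3 in this assay the estimate is 10000 nM, with a range from 4000 nM to 25000 nM.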

Compound 3, half-maximal inhibitory concentration: 18000 nM
For compound 3 the middle estimate is 1.8-fold (0.26 log units) below the measured one, within the range that was stated.
By their numbers in this assay, from the lowest: compounds 2, 1 and 3 (each within the scatter of the next).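

Among the compounds shown here, the first measured change on the benzyl ring, a 1.5-fold higher number from compound 1 to compound 3 (0.18 log units; within the scatter) in this assay, does not separate the two compounds. The place ortho to a large group on this ring therefore accepts a chloro in place of hydrogen with no readable change in this assay, and the step from benzyl to 2-chlorobenzyl joins the methyl step, a 1.2-fold lower number from compound 1 to compound 2 (0.08 log units; within the scatter), as a second single change that stays within the scatter. Nothing measured on these compounds bears on what lies behind this result.

On these data alone, whether this position would respond to any other kind of group remains open: an amine, a carboxylic acid or a longer chain such as a butyl group at the same place on the benzyl ring could show whether it is truly permissive or whether the chloro is simply too small a change to register. With no step yet beyond the scatter, the compounds shown also leave open which part of the shared core, if any, can move the number in this cell assay.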